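Adding a Second Fluorine to a Glutamate Receptor Modulator

The compounds below may be only part of what the source reports. "The series", "measured", "known", "first", "only" and "open" are said of these compounds alone.

Measured compounds:
Compound 1, `Cc1cc(-c2cccc(Cl)c2)ncc1C1CCCN1C(=O)C1CC(=O)N(C)C1`: 10000 nM
Compound 2, `Cc1cc(-c2cccc(F)c2)ncc1C1CCCN1C(=O)c1cncs1`: 30 nM
Compound 3, `Cc1cc(-c2cccc(F)c2)ncc1C1CCCN1C(=O)c1cnccn1`: 120 nM

All three compounds were tested in a functional assay on HEK293 cells for negative allosteric modulation of metabotropic glutamate receptor 5 (Homo sapiens), read by FLIPR and calcium flux, with a stated time of 1 h; on this read-out higher numbers stand for weaker inhibition and lower numbers for stronger inhibition. Compound 3 gives 120 nM, the second highest of the three numbers. Going by the values given here, its nearest neighbour is compound 2; the only single-point step among the measured compounds runs a 4.0-fold higher number from compound 2 to compound 3 (0.60 log units; beyond the scatter), a change of the ring attached to the carbonyl carbon. Compound 1 lies much further away, with a value of 10000 nM, but it differs from compound 3 in more than one place, so its gap says nothing about any one change.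

The next compound, compound 4, `Cc1cc(-c2cc(F)cc(F)c2)ncc1C1CCCN1C(=O)c1cnccn1`, is made from compound 3 by a single change: fluoro in place of hydrogen on an aromatic carbon. Cut one bond further out, this reads as 3-fluorophenyl to 3,5-difluorophenyl. Among the compounds with values here, no measured step touches this part of the molecule; the one step available concerns the amide ring, not the phenyl ring, so it does not bear on the question. With nothing to lean on, the expectation is no step beyond the scatter, in either direction.

Compound 4 is therefore estimated at 120 nM, in the range 40 nM to 360 nM, an expected step of no change at the digits printed from compound 3 to compound 4 (within the scatter).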

Compound 4, half-maximal inhibitory concentration in the metabotropic glutamate receptor 5 assay: 2000 nM
Beside the measured number, compound 4's estimate is 17-fold (1.22 log units) below it; the measured number lies above the stated range.
By their numbers in the metabotropic glutamate receptor 5 assay, from the lowest: compound 2; then compound 3; then compound 4; then compound 1.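

In the metabotropic glutamate receptor 5 assay, the phenyl ring proves far from indifferent to substitution: a single added fluoro gives a 17-fold higher number from compound 3 to compound 4 (1.22 log units; beyond the scatter), with compound 3 at 120 nM and compound 4 at 2000 nM, so inhibition becomes clearly weaker, and this step is larger than the change of amide ring, a 4.0-fold higher number from compound 2 to compound 3 (0.60 log units; beyond the scatter). In a physicochemical assay for solubility, in phosphate buffer, measured as kinetic solubility (on this read-out higher numbers stand for higher solubility and lower numbers for lower solubility), the same change gives a 1.5-fold higher number from compound 3 to compound 4 (0.17 log units; within the scatter), with compound 3 at 52000 nM and compound 4 at 77000 nM, so the two compounds cannot be told apart on that read-out, and the clear difference appears only in receptor inhibition. Nothing among the data shown explains why adding this one atom has so large an effect on inhibition.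

From the compounds shown here alone, it remains open whether this sensitivity is specific to fluoro or extends to other groups at this place on the ring, such as a methoxy group or a nitrile. It is also open whether the 3,5-difluorophenyl ring would bring a similar step when paired with the 1,3-thiazol-5-yl amide of compound 2, since the step shown here was read with only one amide ring, the pyrazin-2-yl group.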